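Swapping the carboxy-bearing ring of compound 2

The source may hold more compounds than are shown below. What is called first, only, known or untested is meant among the compounds shown, and "the series" means these compounds.

- Compound 1 `O=C(/C(=C\c1cc(I)c(O)c(I)c1)SCc1ccc(Br)cc1)c1ccc(Br)cc1`: 1000 nM
- Compound 2 `O=C(/C(=C\c1ccc(O)c(C(=O)O)c1)SCc1ccc(Br)cc1)c1ccc(Br)cc1`: 10000 nM

In a functional assay on DU-145 cells (Homo sapiens) for inhibition, read by trypan blue exclusion, with a stated time of 96 h (on this read-out lower numbers stand for stronger inhibition of growth and higher numbers for weaker inhibition of growth), compound 2 gives 10000 nM, the higher of the two numbers and so the weaker growth inhibition. Compound 3 `O=C(/C(=C\c1cc(Cl)c(O)c(Cl)c1)SCc1ccc(Br)cc1)c1ccc(Br)cc1` differs from it in one place: 3,5-dichloro-4-hydroxyphenyl in place of 3-carboxy-4-hydroxyphenyl on a double-bonded chain carbon bound to a double-bonded chain carbon. Here 3,5-dichloro-4-hydroxyphenyl stands in place of 3-carboxy-4-hydroxyphenyl.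

Among the compounds with values here, one measured step bears on this change: a 10-fold higher number from compound 1 to compound 2 (1.00 log units; beyond the scatter), where 3-carboxy-4-hydroxyphenyl replaced 4-hydroxy-3,5-diiodophenyl. Within the data shown here, the group entering compound 3 resembles the one leaving in that step, with chlorine instead of iodine. Among the measured compounds shown here, no measured pair compares those two halogens, so this comparison is uncertain. A step toward lower numbers is expected, similar in size or somewhat smaller. The expected step is a 6.7-fold lower number from compound 2 to compound 3 (0.82 log units; beyond the scatter). For compound 3 the estimated value is 1500 nM, with an expected range of 500 nM to 5000 nM.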

Compound 3, concentration for 50% growth inhibition: 10000 nM
The estimate for compound 3 lay 6.7-fold (0.82 log units) below the measured number; the measured number lies above the stated range.
By their numbers in this assay, from the lowest: compound 1; then compounds 2 and 3 (each within the scatter of the next).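

In this assay there is a 10-fold higher number from compound 1 to compound 3 (1.00 log units; beyond the scatter), when 3,5-dichloro-4-hydroxyphenyl replaces 4-hydroxy-3,5-diiodophenyl, so at this position chlorine cannot simply stand in for iodine. There is also no change at the digits printed from compound 2 to compound 3 (within the scatter), so the dichloro ring and the 3-carboxy-4-hydroxyphenyl ring cannot be told apart here, and among these three compounds the stronger growth inhibition goes with the diiodo ring alone, not with ring halogens in general. The data offer no measurement that explains why the two halogens part ways.

Still open, going by these compounds, is where a 3,5-dibromo-4-hydroxyphenyl group would fall, and so whether the number shifts stepwise from chlorine to iodine or iodine alone stands apart. Also open, on these data alone, is whether the two iodines would keep this level of inhibition with an amine in place of the ring hydroxyl.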